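The source may hold more compounds than are shown below. What is called first, only, known or untested is meant among the compounds shown, and "the series" means these compounds.

Working notes on the series, with permeability as the only read-out so far. In an ADME assay for permeability, using PAMPA, at pH 7.4 (on this read-out lower numbers stand for lower permeability and higher numbers for higher permeability), compound 1 `CN(Cc1cc(C(F)(F)F)cc(C(F)(F)F)c1)C(=O)c1c(OCCCC2CCN(C(=O)OC3(C)CC3)CC2)c2cccnc2n(C)c1=O` gives 721 nm/s and compound 2 `COc1cc(CN(C)C(=O)c2c(OCCCC3CCN(C(=O)OC4(C)CC4)CC3)c3cccnc3n(C)c2=O)cc(OC)c1` gives 200 nm/s as the lower of the two numbers. The gap between them lies beyond the usual scatter, so compound 2 stands at the bottom of this small set.

Still unmeasured is compound 3 `COc1cc(CN(C)C(=O)c2c(OCCCC3CCN(C(=O)OC4(C)CC4)CC3)c3cccnc3n(C)c2=O)cc(C(F)(F)F)c1`, which keeps the shared core of compound 2 and differs from it in one place: trifluoromethyl in place of methoxy on an aromatic carbon, meta to a large group and meta to a methoxy group. For the measured compounds named here, no measured step isolates this change, so its size in this assay can only be expected. A rise is expected because compound 1 at 721 nm/s stands above compound 2 at 200 nm/s, and compound 3 is expected to land between those two values. The estimated change is a 1.9-fold higher number from compound 2 to compound 3 (0.28 log units; within the scatter), an expected rise that stays just within the scatter. For compound 3 the estimate is 380 nm/s, with an expected range from 210 nm/s to 700 nm/s.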

Compound 3, apparent permeability: 424 nm/s
Beside the measured number, compound 3's estimate is 1.1-fold (0.05 log units) below it, and the stated range covers the measured number.
By their numbers in this assay, from the lowest: compound 2; then compounds 3 and 1 (each within the scatter of the next).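

In this assay, trifluoromethyl in place of methoxy on an aromatic carbon, meta to a large group and meta to a methoxy group, gives a 2.1-fold higher number from compound 2 to compound 3 (0.33 log units; beyond the scatter) as an isolated measure of this change at this position, and it is a modest one. The opposite exchange, methoxy in place of trifluoromethyl on an aromatic carbon, gives a 1.7-fold lower number from compound 1 to compound 3 (0.23 log units; within the scatter) and so cannot be told apart from repeat variation in the measurement. The same kind of exchange on this ring therefore reads beyond the scatter in one pair of compounds and within it in the other, while no measurement on hand gives a reason for either step.

The compounds shown leave open how other groups on this aromatic carbon would read in this assay, for example a nitrile, a chlorine atom, an amine or a carboxylic acid. On these data alone, all three compounds also keep the rest of the structure unchanged, so it remains open whether these steps keep their size when another part of the shared core is changed.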